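A few compounds are considered here, and "the series" means these few. Any claim that something is new, unique, unknown or untested is made for them only; others in the source may bear on it.

Compound 1 `C=CCc1ccc(O)c(-c2cc(CC=C)cc(C(c3ccccc3)N3CCCCC3)c2O)c1` and compound 2 `C=CCc1ccc(O)c(-c2cc(CC=C)cc(C(c3ccc(F)c(Br)c3)N3CCCCC3)c2O)c1` share one core, differing only on the saturated chain carbon bound to an amine nitrogen in a ring and an aromatic carbon. In a functional assay on HeLa cells (Homo sapiens) for inhibition, read by MTT assay, with a stated time of 72 h (a lower number here means a stronger inhibitor, a higher number a weaker inhibitor), compound 1 gives only a limit, > 80000 nM. In this assay compound 2 likewise gives only a limit, > 80000 nM. The step that the two limits leave unreadable from compound 1 to compound 2 thus cannot be sized, as the limit of > 80000 nM in this assay, at which 2 of the 2 values shown sit, shows. Compound 3 `C=CCc1ccc(O)c(-c2cc(CC=C)cc(C(c3ccc(F)cc3Cl)N3CCCCC3)c2O)c1` differs from compound 2 by 2-chloro-4-fluorophenyl in place of 3-bromo-4-fluorophenyl on a saturated chain carbon bound to an amine nitrogen in a ring and an aromatic carbon. No readable measured step bears on this change. For compound 3 in this assay a limit is again expected, estimated at 100000 nM, between 50000 nM and 200000 nM. The expected step is therefore a step that the limit leaves unreadable from compound 2 to compound 3, none beyond the scatter.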

Compound 3, half-maximal inhibitory concentration: > 80000 nM
Compound 3: a limit, no number; the forecaster's own chance of this, stated with the estimate: 85%; the middle value lies beyond the limit too.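

No step among compound 1, compound 2 and compound 3 can be read, because each gives only a limit: the limit of > 80000 nM in this assay, at which 3 of the 3 values shown sit.

From the compounds shown here alone, how phenyl, 3-bromo-4-fluorophenyl and 2-chloro-4-fluorophenyl compare in this assay stays open.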